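This account rests on a few compounds, and the source may have more. Where it says the series, first, only, none or still open, it means among the compounds named here.

Working notes on the series.

Compound 1 `COc1ccc(C(=O)c2cc(OC)c(OC)c(OC)c2)c(NC(=O)CO)c1` and compound 2 `COc1ccc(C(=O)c2cc(OC)c(OC)c(OC)c2)c(NC(=O)CN(C)C)c1` share one core and differ only in the chain on the amide. In a functional assay on MCF7 cells (Homo sapiens) for antiproliferative activity, read by MTT assay, with a stated time of 48 h (on this read-out lower numbers stand for stronger inhibition and higher numbers for weaker inhibition), compound 1 gives 230 nM, and compound 2 gives 790 nM. The step of a 3.4-fold lower number from compound 2 to compound 1 (0.54 log units; beyond the scatter) is the change (hydroxy in place of dimethylamino on a saturated chain carbon bound to a carbonyl carbon).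

Compound 3 `C=C(c1cc(OC)c(OC)c(OC)c1)c1ccc(OC)c(O)c1NC(=O)CN(C)C` sits on a second core; how the two cores differ is not broken down here. In this assay compound 3 gives 210 nM, a number within the scatter of compound 1 and beyond the scatter from compound 2.

Compound 4 `C=C(c1cc(OC)c(OC)c(OC)c1)c1ccc(OC)c(O)c1NC(=O)CO` is compound 3 carrying the same change, (hydroxy in place of dimethylamino on a saturated chain carbon bound to a carbonyl carbon), at the same place. Its result in this assay is still to be read. Within the data shown here, the expected step of a 2.1-fold lower number from compound 3 to compound 4 (0.32 log units; beyond the scatter) rests on the one earlier instance of this change, the step of a 3.4-fold lower number from compound 2 to compound 1 (0.54 log units; beyond the scatter) on the other core, and is taken somewhat smaller, since only one pair supports it and the second core may not carry the change the same way. Compound 4 is therefore estimated at 100 nM, with a range from 40 nM to 260 nM expected.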

Compound 4, half-maximal inhibitory concentration: 50 nM
Compound 4: middle estimate off by 2.0-fold (0.30 log units), on the high side; measured number inside the range.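

In this assay, hydroxy in place of dimethylamino on a saturated chain carbon bound to a carbonyl carbon gives a 4.2-fold lower number from compound 3 to compound 4 (0.62 log units; beyond the scatter) and matches in size the step on the core of compound 1: the same change on two cores in this assay, a 3.4-fold lower number (0.54 log units; beyond the scatter) from compound 2 to compound 1 and a 4.2-fold lower number (0.62 log units; beyond the scatter) from compound 3 to compound 4, 1.2-fold (0.09 log units) apart, within the scatter of two such steps. On these two pairs, the change carries from one core to the other with its size preserved within the scatter, and the starting core does not visibly alter the step. This does not show that the change would carry to a third core or to another assay, since two pairs are a narrow base, and the numbers alone give no reason for the step.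

As far as these compounds go, it remains open whether the lower number depends on the hydroxy itself or on the loss of dimethylamino, a question that a methoxy or a primary amine on the same chain carbon could help to separate. Also open, from the compounds shown here alone, is how a carboxylic acid in that place, or a longer chain ending in hydroxy, would read in this assay on either core.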